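Nitro to amino in a sulfone series: growth inhibition

The source may report more compounds than this note shows. Statements on the series, on what has been measured and on what is new or still open speak of the compounds shown alone.

In an ADME assay on MRC5 cells (Homo sapiens) for cytotoxicity, read by MTT assay, with a stated time of 72 h (on this read-out higher numbers stand for weaker inhibition of growth and lower numbers for stronger inhibition of growth), compound 1 `COc1ccc(CS(=O)(=O)/C=C/c2c(OC)cccc2OC)cc1[N+](=O)[O-]` reaches only the assay limit, > 30000 nM.
In this assay compound 2 `COc1ccc(CS(=O)(=O)/C=C/c2ccc(OC)c(OC)c2OC)cc1[N+](=O)[O-]` likewise gives only a limit, > 30000 nM.
In this assay compound 3 `COc1ccc(CS(=O)(=O)/C=C/c2ccc(OC)c(OC)c2OC)cc1N` also gives only a limit, > 30000 nM.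

The change from compound 2 to compound 3 is amino in place of nitro on an aromatic carbon. Its size in this assay is a step that the two limits leave unreadable from compound 2 to compound 3, as both compounds sit at the limit of > 30000 nM in this assay, at which 3 of the 3 values shown sit. The difference between the core of compound 1 and the core of compound 2 is not broken down here. Compound 4 `COc1ccc(CS(=O)(=O)/C=C/c2c(OC)cccc2OC)cc1N` has not been measured; it arises from compound 1 by amino in place of nitro on an aromatic carbon, the same change as that made from compound 2 to compound 3. In this assay the step from compound 1 to compound 4 is expected to be a step that the limit leaves unreadable from compound 1 to compound 4, set beside a step that the two limits leave unreadable from compound 2 to compound 3, resting on compound 1 sitting at the limit of > 30000 nM in this assay, at which 3 of the 3 values shown sit. Compound 4 is therefore expected to give about 45000 nM, estimated between 15000 nM and 150000 nM, most likely again reported only as a limit.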

Compound 4, concentration for 50% growth inhibition: 17100 nM
For compound 4 the middle estimate is 2.6-fold (0.42 log units) above the measured one; the range from low to high includes it.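

In this assay, amino in place of nitro on the core of compound 1 gives an at least 1.7-fold lower number from compound 1 to compound 4 (0.24 log units; that floor lies within the scatter) and so yields a measured number, although the size of this step is not shown to lie beyond the usual scatter. On the core of compound 2, the same change leads to compound 3, which gives only the limit > 30000 nM and no number. The step on that core therefore cannot be read, and the data do not show whether the change carries from one core to the other, because the nitro compounds and compound 3 all stop at the limit: the limit of > 30000 nM in this assay, at which 3 of the 4 values shown sit.

Going by these compounds, it remains open how an acetamide or a methylamino group on that aromatic carbon would compare with the amino group of compound 4. The compounds shown also leave open whether a hydroxyl group there would give a number on either core.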